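Cytotoxicity notes: nitro to dimethylamino swap

A few compounds are considered here, and "the series" means these few. Any claim that something is new, unique, unknown or untested is made for them only; others in the source may bear on it.

compound 1 `CC(=O)N1N=C(c2ccco2)CC1c1ccccc1[N+](=O)[O-]`: 47900 nM
compound 2 `CC(=O)N1N=C(c2ccco2)CC1c1ccc([N+](=O)[O-])cc1`: 21800 nM

In a functional assay on HEp-2 cells (Homo sapiens) for cytotoxicity, read by sulforhodamine B assay, with a stated time of 48 h (a higher number here means a weaker inhibitor, a lower number a stronger inhibitor), compound 2 gives 21800 nM, the lower of the two numbers measured; compound 1 gives 47900 nM, a gap beyond the scatter. Compound 3 `CC(=O)N1N=C(c2ccco2)CC1c1ccc(N(C)C)cc1` differs from compound 2 by dimethylamino in place of nitro on an aromatic carbon. Going by the values given here, no measured pair shows this change, so nothing fixes its direction; a small step either way, or none beyond the scatter, is the plain expectation. The expected step is a 1.4-fold higher number from compound 2 to compound 3 (0.14 log units; within the scatter). Compound 3 is estimated at 30000 nM, with a range from 10000 nM to 90000 nM.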

Compound 3, half-maximal inhibitory concentration: 16000 nM
Beside the measured number, compound 3's estimate is 1.9-fold (0.27 log units) above it; low and high end bracket the measured number.
By their numbers in this assay, from the lowest: compounds 3 and 2 (each within the scatter of the next); then compound 1.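

In this assay, dimethylamino in place of nitro, para to a large group, gives a 1.4-fold lower number from compound 2 to compound 3 (0.13 log units; within the scatter), so the two groups read alike at this position. The series now shows that this position accepts a change of nitro to dimethylamino with no step beyond the scatter. No available evidence bears on the reason for this result.

From the compounds shown here alone, whether a primary amine, a methoxy group or a carboxylic acid at this position would stay within the scatter remains open. Also open, going by these compounds, is whether dimethylamino would match nitro at the place it occupies in compound 1.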